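This account rests on a few compounds, and the source may have more. Where it says the series, first, only, none or still open, it means among the compounds named here.

Among the measured compounds shown here, in an ADME assay on L6 cells (Rattus norvegicus) for cytotoxicity (on this read-out higher numbers stand for weaker inhibition and lower numbers for stronger inhibition), compound 2 `O=C(CN1CCCCC1)OC1CC2(N3CCCC3)CC(c3ccccc3)C1C(c1ccccc1)C2` gives 14200 nM, the lower of the two single numbers so far. Compound 1 `O=C(CN1CCCC1)OC1CC2(N3CCCC3)CC(c3ccccc3)C1C(c1ccccc1)C2` gives 42900 nM. Compound 3 `O=C(CN1CCCCC1)OC1CC2(N3CCCCC3)CC(c3ccccc3)C1C(c1ccccc1)C2` gives 60400 nM; > 184000 nM (2 entries). The entries of compound 3 with a sign are a limit of the assay, not a number.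

Compound 4 `O=C(CCN1CCCC1)OC1CC2(N3CCCC3)CC(c3ccccc3)C1C(c1ccccc1)C2` has the same atoms as compound 2, joined differently: (pyrrolidin-1-yl)methyl in place of piperidin-1-yl on a saturated chain carbon bound to a carbonyl carbon. The measured step that bears on this is a 3.0-fold lower number from compound 1 to compound 2 (0.48 log units; beyond the scatter), which put piperidin-1-yl in place of pyrrolidin-1-yl. For the measured compounds named here, compound 4 goes back to the five-membered ring, so a modest move to a higher number seems likely, although the change from (piperidin-1-yl)methyl to 2-(pyrrolidin-1-yl)ethyl has no measured step of its own. The step expected in this assay is a 1.9-fold higher number from compound 2 to compound 4 (0.28 log units; within the scatter). For compound 4 the estimated value is 27000 nM, with an expected range of 9000 nM to 80000 nM.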

Compound 4, half-maximal inhibitory concentration: 21900 nM
Estimate against measurement, compound 4: 1.2-fold (0.09 log units) above; low and high end bracket the measured number.
By their numbers in this assay, from the lowest: compounds 2, 4 and 1 (each within the scatter of the next, the first and the last beyond it).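

In this assay, extending the chain to 2-(pyrrolidin-1-yl)ethyl gives a 2.0-fold lower number from compound 1 to compound 4 (0.29 log units; within the scatter), and the same chain set against (piperidin-1-yl)methyl gives a 1.5-fold higher number from compound 2 to compound 4 (0.19 log units; within the scatter). Both steps lie within the scatter, so compound 4 cannot be ranked against either of these two, even though the step between them lies beyond it. No measurement shown explains these differences.

Still open, from the compounds shown here alone, is how a 2-(piperidin-1-yl)ethyl group or a longer chain such as 3-(pyrrolidin-1-yl)propyl would read at this place.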